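The compounds below may be only part of what the source reports. "The series", "measured", "known", "first", "only" and "open" are said of these compounds alone.

Series notes. Among the measured compounds shown here, the two measured members are compound 1 `CC(C)(c1ccccc1)c1nc2c(C(F)(F)F)cccc2c(C(=O)O)c1O` and compound 2 `Cc1cc(C)c2nc(C3(c4ccc(Cl)cc4)CC3)c(O)c(C(=O)O)c2c1`. In an assay on isolated protein for inhibition of P-selectin glycoprotein ligand 1 (Homo sapiens), read by surface plasmon resonance, tested at 250 uM (on this read-out higher numbers stand for more inhibition at the one concentration tested (going by the name of the read-out) and lower numbers for less inhibition), compound 1 gives 59%, the higher of the two numbers recorded so far. In this assay compound 2 gives 47%, a figure that lies below that of compound 1 by more than the usual scatter. For the measured compounds named here, compound 2 differs from compound 1 in more than one place, so no single step is traced between them; their two values show only that compound 1 stands ahead.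

The next member is compound 3 `O=C(O)c1c(O)c(C2(c3ccsc3)CC2)nc2c(C(F)(F)F)cccc12`. Relative to compound 1 the change is 1-(thiophen-3-yl)cyclopropyl in place of 1-methyl-1-phenylethyl on an aromatic carbon. Going by the values given here, no measured pair isolates a change of this kind, so the expectation rests on compound 1 alone. In this assay the step from compound 1 to compound 3 is expected to be a modest fall a number 9 percentage points lower from compound 1 to compound 3 (within the scatter), hardly beyond the scatter. For compound 3 the expected inhibition in this assay is 50%, within a range from 30% to 70%.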

Compound 3, a percentage reported as inhibition, at one concentration (the size of the read-out at that concentration, not a potency): 7%
Beside the measured number, compound 3's estimate is 43 percentage points above it; the whole stated range lies above it.
By their numbers in this assay, from the lowest: compound 3; then compound 2; then compound 1.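

In this assay the position on the aromatic carbon next to the ring nitrogen proves sensitive to the group it carries: 1-(thiophen-3-yl)cyclopropyl in place of 1-methyl-1-phenylethyl gives a number 52 percentage points lower from compound 1 to compound 3 (beyond the scatter) in a single exchange. That exchange alters both the aromatic ring of the group and the carbon linking it to the core, so this one step cannot divide the loss between the two. No measurement bearing on the cause of this step is available.

Open, as far as these compounds go, is whether 1-phenylcyclopropyl or 1-methyl-1-(thiophen-3-yl)ethyl at this position would stand nearer compound 1 or compound 3, which would separate the ring exchange from the link exchange. Also open, from the compounds shown here alone, is how a plain tert-butyl group, with no aromatic ring, would read at the same position.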